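The source may hold more compounds than are shown below. What is called first, only, known or untested is meant among the compounds shown, and "the series" means these compounds.

In an ADME assay on microsomes from liver (Mus musculus) for pharmacokinetics, read by LC-MS, using NADPH, with stated times of 5 min, 15 min and 30 min, tested at 10 uM (a higher number here means faster removal of the compound, a lower number slower removal), compound 1 (`C[C@@H](c1ccc(NC(=O)N2CC(c3cccnc3)C2)cc1)N1Cc2ccccc2C1=O`) gives 123 mL.min-1.g-1, compound 2 (`C[C@H](NC(=O)c1cccc(F)c1)c1ccc(NC(=O)N2CC(c3cccnc3)C2)cc1`) gives 60.9 mL.min-1.g-1 and compound 3 (`C[C@H](NC(=O)c1ncccn1)c1ccc(NC(=O)N2CC(c3cccnc3)C2)cc1`) gives 28.9 mL.min-1.g-1, the lowest of the three numbers. Compound 4 (`C[C@H](NC(=O)[C@@H]1CCCN1C)c1ccc(NC(=O)N2CC(c3cccnc3)C2)cc1`) has not yet been measured. It differs from compound 3 in one place: 1-methylpyrrolidin-2-yl in place of pyrimidin-2-yl on a carbonyl carbon. In words, 1-methylpyrrolidin-2-yl stands in place of pyrimidin-2-yl on a carbonyl carbon. The closest guide is the change at that same carbonyl carbon, where pyrimidin-2-yl replaced 3-fluorophenyl: a 2.1-fold lower number from compound 2 to compound 3 (0.32 log units; beyond the scatter). Two further steps, a 2.0-fold lower number from compound 1 to compound 2 (0.31 log units; beyond the scatter) and a 4.3-fold lower number from compound 1 to compound 3 (0.63 log units; beyond the scatter), changed a larger group and were also modest. None of these compounds carries 1-methylpyrrolidin-2-yl, so the direction is uncertain. Among the compounds with values here, compound 3 has the lowest number so far, and a 2.1-fold lower number from compound 2 to compound 3 (0.32 log units; beyond the scatter) shows that pyrimidin-2-yl gave the lower number in that comparison, so a small upward move is expected. The expected step is a 1.6-fold higher number from compound 3 to compound 4 (0.19 log units; within the scatter), which would not stand clearly apart from the usual scatter. For compound 4 the estimated value is 45 mL.min-1.g-1, with an expected range from 18 mL.min-1.g-1 to 110 mL.min-1.g-1.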

Compound 4, intrinsic clearance in microsomes: 40.8 mL.min-1.g-1
Compound 4: the middle estimate sits 1.1-fold (0.04 log units) above what was measured; measured number inside the range.
By their numbers in this assay, from the lowest: compounds 3, 4 and 2 (each within the scatter of the next, the first and the last beyond it); then compound 1.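

In this assay, within the data shown here, compound 4 is the only compound here with a non-aromatic ring on this carbonyl carbon, and its steps (a 1.4-fold higher number from compound 3 to compound 4 (0.15 log units; within the scatter); a 1.5-fold lower number from compound 2 to compound 4 (0.17 log units; within the scatter)) do not set 1-methylpyrrolidin-2-yl clearly apart from either aromatic group. The number at this position therefore stays within the scatter of both compound 2 and compound 3 without a six-membered aromatic ring there, even though those two stand beyond the scatter of each other. The larger replacement in the other step also holds for this new group (a 3.0-fold lower number from compound 1 to compound 4 (0.48 log units; beyond the scatter)), but no measurement here explains any of these numbers.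

Still open, from the compounds shown here alone, is whether the methyl on the ring nitrogen matters, as pyrrolidin-2-yl would show. Also open, going by these compounds, is how the mirror-image form of 1-methylpyrrolidin-2-yl or an open-chain amine would behave at this carbonyl carbon.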